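The source may report more compounds than this note shows. Statements on the series, on what has been measured and on what is new or still open speak of the compounds shown alone.

Working notes on the series.

Going by the values given here, compound 1 `Cc1nc(N[C@H](C)c2ccccc2)nc(N[C@@H]2C[C@H](CO)[C@@H](O)[C@H]2O)c1-c1nc2cnccc2s1` is the only member of the series with a number in hand. In an ADME assay on the whole organism (plasma) for pharmacokinetics, with Rattus norvegicus as the target, with a stated time of 6 h, at a dose of 10 mg/kg by the oral route (a higher number here means more compound in the circulation at the dose given, a lower number less compound in the circulation), compound 1 gives 98.5 ng.h/mL. Compound 2 `Cc1ccc(C2(Nc3nc(C)c(-c4nc5cnccc5s4)c(N[C@@H]4C[C@H](CO)[C@@H](O)[C@H]4O)n3)CC2)cc1`, which carries a different substituent on the shared core, has a result of "not determined" (no result reported) in this assay, so compound 1 stands alone and no comparison within the measured set is possible.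

Compound 3 `Cc1nc(N[C@H](C)c2ccccc2OC(F)(F)F)nc(N[C@@H]2C[C@H](CO)[C@@H](O)[C@H]2O)c1-c1nc2cnccc2s1` is the next compound to be measured. It differs from compound 1 in one place: trifluoromethoxy in place of hydrogen on an aromatic carbon. The change is small, adding five heavy atoms and one hydrogen-bond acceptor to the phenyl group, with the rest of the shared core unchanged.

Among the compounds with values here, with no measured pair to calibrate this kind of change, the expectation rests on compound 1 alone. The step from compound 1 to compound 3 is expected to be modest, leaning towards more compound in the circulation but not clearly beyond the scatter of repeated measurements, so that a 1.5-fold higher number from compound 1 to compound 3 (0.18 log units; within the scatter) is expected. Compound 3 is therefore estimated at 150 ng.h/mL in this assay, with a range from 45 ng.h/mL to 500 ng.h/mL.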

Compound 3, area under the concentration-time curve: 288 ng.h/mL
Beside the measured number, compound 3's estimate is 1.9-fold (0.28 log units) below it; the measured number falls inside the stated range.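

Going by these compounds alone, the first step that can be read falls on the phenyl group of compound 1: in this assay, trifluoromethoxy in place of hydrogen on an aromatic carbon, ortho to a large group, gives a 2.9-fold higher number from compound 1 to compound 3 (0.47 log units; beyond the scatter). Substitution at this place on the phenyl group can therefore shift the read-out by more than the usual scatter, which compound 1 alone could not show, although a single pair sets no trend for other groups or other places. Nothing at hand bears on why the number rises with this change.

As far as these compounds go, it remains open whether a smaller group such as fluorine or methoxy on the same carbon would give a step of similar size and direction, or whether the same holds for trifluoromethyl, which differs from trifluoromethoxy by the oxygen. An amine or a carboxylic acid at this place also stands outside the compounds shown, so the effect of such groups on this assay cannot be judged from this pair.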